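Methyl for Methoxy: A Small Swap at the Limit

The compounds below may be only part of what the source reports. "The series", "measured", "known", "first", "only" and "open" are said of these compounds alone.

Three measured compounds share a core, and one more awaits testing in an assay on cells for inhibition of HSP60/HSP10 (Homo sapiens), with a stated time of 60 min; a lower number here means a stronger inhibitor, a higher number a weaker inhibitor. Compound 1 `COc1ccc(S(=O)(=O)Nc2ccc(-c3nc4ccccc4o3)cc2)cc1` carries a methoxy group on its outer ring. In this assay compound 1 gives > 100000 nM, which is a limit of the assay and not a number. Compound 2 `O=S(=O)(Nc1ccc(-c2nc3ccccc3o2)cc1)c1ccc(Cl)c(C(F)(F)F)c1` carries a chlorine and a trifluoromethyl group instead, and in this assay compound 2 gives 12000 nM. Compound 3 `CCc1ccc(S(=O)(=O)Nc2ccc3oc(-c4ccccc4)nc3c2)cc1` bears an ethyl group on a core joined in a different way. In this assay compound 3 gives > 100000 nM, again a limit of the assay rather than a number. Among the compounds with values here, compound 1 thus stands at the limit of > 100000 nM in this assay, at which 2 of the 3 values shown sit, so its true value is not known, and no step between measured compounds is available to guide the next change.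

Compound 4 `Cc1ccc(S(=O)(=O)Nc2ccc(-c3nc4ccccc4o3)cc2)cc1` differs from compound 1 by methyl in place of methoxy on an aromatic carbon. Within the data shown here, no measured pair shows how this swap moves the numbers. The expected step of a number no higher from compound 1 to compound 4 (the limit leaves the size open) is none beyond the scatter. Compound 4 is therefore expected to come out at about 100000 nM, within a range from 30000 nM to 300000 nM, and most likely reported again only as a limit.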

Compound 4, half-maximal inhibitory concentration: > 100000 nM
Compound 4 was reported as a limit; the forecaster's own chance of this, stated with the estimate: 70%; the middle value lies on the limit itself.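

No step from compound 1 to compound 4 can be read, because both are reported only as limits of the assay and not as numbers: the limit of > 100000 nM in this assay, at which 3 of the 4 values shown sit.

The compounds shown leave open whether methyl in place of methoxy on an aromatic carbon changes the result in this assay at all.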